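The compounds below may be only part of what the source reports. "The series", "measured", "known", "first", "only" and "open" are said of these compounds alone.

Compound 2 `CCN(CC)c1ccc2cc(C(=O)c3ccc(N4CCN(C(=O)CN5CCN(Cc6ccc(C(F)(F)F)cc6)CC5)CC4)cc3)oc2c1` gives the highest number of the two measured in a functional assay on A549 cells (Homo sapiens) for cytotoxicity, read by MTT assay, with a stated time of 48 h (a lower number here means a stronger inhibitor, a higher number a weaker inhibitor), at 20100 nM. Its nearest neighbour, compound 1 `CCN(CC)c1ccc2cc(C(=O)c3ccc(N4CCN(C(=O)CN5CCN(Cc6ccc(/C=C/C(=O)OC)cc6)CC5)CC4)cc3)oc2c1`, gives 2810 nM in this assay. Compound 3 `CCN(CC)c1ccc2cc(C(=O)c3ccc(N4CCN(C(=O)CN5CCN(CC(C)=O)CC5)CC4)cc3)oc2c1` has not yet been measured; it differs from compound 2 by acetyl in place of 4-(trifluoromethyl)phenyl on a saturated chain carbon bound to an amine nitrogen in a ring. Within the data shown here, the only comparable step, a 7.2-fold higher number from compound 1 to compound 2 (0.85 log units; beyond the scatter), exchanged one group on that same aromatic ring, whereas here the whole ring leaves. On this thin basis the expected step of a 1.3-fold lower number from compound 2 to compound 3 (0.13 log units; within the scatter) is small, in either direction. For compound 3 the estimate is 15000 nM, within the range 4000 nM to 60000 nM.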

Compound 3, half-maximal inhibitory concentration: 8920 nM
For compound 3 the middle estimate is 1.7-fold (0.23 log units) above the measured one; the range from low to high includes it.
By their numbers in this assay, from the lowest: compound 1; then compound 3; then compound 2.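

In this assay, the aromatic ring at this position proves dispensable for activity: replacing 4-(trifluoromethyl)phenyl with the much smaller acetyl gives a 2.3-fold lower number from compound 2 to compound 3 (0.35 log units; beyond the scatter). The ring can still be the better choice, depending on what it carries, since acetyl in place of 4-(2-(methoxycarbonyl)ethenyl)phenyl gives a 3.2-fold higher number from compound 1 to compound 3 (0.50 log units; beyond the scatter). No supporting data explain either step. Going by these compounds, it remains open how an unsubstituted phenyl would compare on the same saturated chain carbon. Also open, on these data alone, is whether a carboxylic acid or an amine in place of acetyl would raise or lower the number.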